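Swapping an Imidazole Amide for an Acetylpiperidine

The compounds below may be only part of what the source reports. "The series", "measured", "known", "first", "only" and "open" are said of these compounds alone.

Compound 3 `CNC(=O)c1ncc(-c2cnc(NCc3c(F)ccc4c3CCO4)c3cn[nH]c(=O)c23)n1C` stands lowest of the three numbers measured in a physicochemical assay for lipophilicity, using the shake flask method, in phosphate buffer, measured as octanol-water partition, with a stated time of 30 min, at pH 7.4 (on this read-out lower numbers stand for lower lipophilicity and higher numbers for higher lipophilicity), giving 2.5. Compound 1 `Cn1cc(-c2cnc(NCc3c(F)ccc4c3CCO4)c3cn[nH]c(=O)c23)cn1` gives 2.7 in this assay, and compound 2 `CNC(=O)c1ccc(-c2cnc(NCc3c(F)ccc4c3CCO4)c3cn[nH]c(=O)c23)c(C)n1` gives 2.9. Compound 4 `CC(=O)N1CCC(c2cnc(NCc3c(F)ccc4c3CCO4)c3cn[nH]c(=O)c23)CC1` differs from compound 3 in one place: 1-acetylpiperidin-4-yl in place of 1-methyl-2-(methylcarbamoyl)-1H-imidazol-5-yl on an aromatic carbon. Each measured step swaps one aromatic ring for another, so none matches this change closely. They were all small: a number 0.20 log units higher from compound 1 to compound 2 (within the scatter), a number 0.20 log units lower from compound 1 to compound 3 (within the scatter) and a number 0.40 log units lower from compound 2 to compound 3 (beyond the scatter). Given that even the largest of these, a number 0.40 log units lower from compound 2 to compound 3 (beyond the scatter), was modest, a small step is expected here, a number 0.20 log units lower from compound 3 to compound 4 (within the scatter), leaning downward but possibly within the scatter. Compound 4 is therefore estimated at 2.3, with a range from 1.8 to 2.8.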

Compound 4, distribution coefficient: 2.9
Compound 4: middle estimate off by 0.60 log units, on the low side; measured number above the stated range.
By their numbers in this assay, from the lowest: compounds 3, 1, 2 and 4 (each within the scatter of the next, the first and the last beyond it).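

Only one compound shown carries a non-aromatic ring at this position, and in this assay 1-acetylpiperidin-4-yl brings a number 0.40 log units higher from compound 3 to compound 4 (beyond the scatter). Set against the other two aromatic groups, it brings no change at the digits printed from compound 2 to compound 4 (within the scatter) and a number 0.20 log units higher from compound 1 to compound 4 (within the scatter), so giving up the aromatic ring here need not lower the number. Nothing shown explains these steps. Still open, going by these compounds, is how this assay would respond to a piperidine with a free amine, or to a carboxylic acid or a longer chain in place of the acetyl group.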